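From hydroxy to bromo on the shared core

A few compounds are considered here, and "the series" means these few. Any claim that something is new, unique, unknown or untested is made for them only; others in the source may bear on it.

Within the data shown here, compound 2 `CSc1ccc(C2=C(c3ccc(O)cc3)C(=O)N3CCCC3C2)cc1` sits at the high end of the numbers so far. In a functional assay on DU-145 cells (Homo sapiens) for cytotoxicity (on this read-out lower numbers stand for stronger inhibition of growth and higher numbers for weaker inhibition of growth), compound 2 gives > 100000 nM as a limit of the assay and not a number. In this assay compound 1 `COc1ccc(C2=C(c3ccc(SC)cc3)CC3CCCN3C2=O)cc1C` gives 900 nM as a true reading. Compound 3 `CSc1ccc(C2=C(c3ccc(Br)cc3)C(=O)N3CCCC3C2)cc1` has bromo in place of hydroxy on an aromatic carbon and keeps the rest of compound 2 unchanged. Among the measured compounds shown here, the one measured step that bears on this is an at least 110-fold higher number from compound 1 to compound 2 (2.04 log units; beyond the scatter) and it is large and brought the hydroxy in. Removing the hydroxy should therefore undo much of that step, though bromo is not the group compound 1 carries. The expected change is an at least 25-fold lower number from compound 2 to compound 3 (1.39 log units; beyond the scatter) and would be large and toward a lower number. For compound 3 the estimate is 4000 nM with an expected range from 700 nM to 40000 nM in this read-out.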

Compound 3, concentration for 50% growth inhibition: 9000 nM
Estimate against measurement, compound 3: 2.3-fold (0.35 log units) below; the range from low to high includes it.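

Bromo in place of hydroxy on this aromatic carbon gives an at least 11-fold lower number from compound 2 to compound 3 (1.04 log units; beyond the scatter) in this assay, so compound 3 returns to a measurable reading even without the 4-methoxy-3-methylphenyl group that compound 1 carries. The recovery is only partial, and 4-bromophenyl in place of 4-methoxy-3-methylphenyl still leaves a 10-fold higher number from compound 1 to compound 3 (1.00 log units; beyond the scatter) and so does not match that group. Compound 2 stands at a limit of the assay and not at a number, so the step out of it gives only a bound: the limit of > 100000 nM in this assay, at which 1 of the 3 values shown sits.

The compounds shown do not tell whether the methoxy or the methyl carries the gap between compound 1 and compound 3. From the compounds shown here alone, whether an amine or a carboxylic acid on this aromatic carbon would read nearer to compound 2 or to compound 3 also stays open.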